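Sugar-bearing N-oxide core: from protected diol to free hexose

This account rests on a few compounds, and the source may have more. Where it says the series, first, only, none or still open, it means among the compounds named here.

Measured compounds:
Compound 1 `CN1CCN(CCCCCn2c3c(c4ccccc42)C(=O)c2c[n+]([O-])c4ccccc4c2C3=O)CC1`: 1710 nM
Compound 2 `CC1(C)O[C@@H](CO)[C@H](Cn2cc(Cn3c4c(c5ccccc53)C(=O)c3c[n+]([O-])c5ccccc5c3C4=O)nn2)O1`: 190 nM
Compound 3 `O=C1c2c[n+]([O-])c3ccccc3c2C(=O)c2c1c1ccccc1n2CCCCN1CCCCC1`: 190 nM

Of the compounds shown here, three with a shared core have been tested in a functional assay on A-375 cells (Homo sapiens) for cytotoxicity, read by MTT assay, with a stated time of 72 h; a lower number here means a stronger inhibitor, a higher number a weaker inhibitor. Compound 1 gives 1710 nM and compound 3 gives 190 nM, the step being a 9.0-fold lower number from compound 1 to compound 3 (0.95 log units; beyond the scatter). Compound 2 gives 190 nM, level with compound 3 at the digits shown and, together with it, the lowest of the three numbers; compound 1 lies well away from it.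

Compound 4 `O=C1c2c[n+]([O-])c3ccccc3c2C(=O)c2c1c1ccccc1n2Cc1cn([C@@H]2O[C@H](CO)[C@@H](O)[C@H](O)[C@H]2O)nn1` differs from compound 2 only at the triazole: 3,4,5-trihydroxy-6-(hydroxymethyl)oxan-2-yl in place of (5-(hydroxymethyl)-2,2-dimethyl-1,3-dioxolan-4-yl)methyl on an aromatic nitrogen.

Among the measured compounds shown here, the one measured step, from compound 1 to compound 3, concerns a chain amine and has no bearing on an exchange at the triazole nitrogen. For the measured compounds named here, there is therefore no step to lean on, and the expectation for compound 4 must be cautious: its value is expected to sit near that of compound 2, with the step of a 2.1-fold higher number from compound 2 to compound 4 (0.32 log units; beyond the scatter) expected to remain close to the scatter, and a wide range allowed. The estimate for compound 4 is 400 nM, from 120 nM to 1500 nM.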

Compound 4, half-maximal inhibitory concentration: 230 nM
Beside the measured number, compound 4's estimate is 1.7-fold (0.24 log units) above it, within the range that was stated.
By their numbers in this assay, from the lowest: compounds 2, 3 and 4 (each within the scatter of the next); then compound 1.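

In this assay, among the compounds shown here, the first reading at this position, on an aromatic nitrogen of a five-membered aromatic ring with 3 nitrogen, is a 1.2-fold higher number from compound 2 to compound 4 (0.08 log units; within the scatter). The 3,4,5-trihydroxy-6-(hydroxymethyl)oxan-2-yl group, with 4 hydrogen-bond donors and a six-membered ring, therefore cannot be told apart in this assay from the (5-(hydroxymethyl)-2,2-dimethyl-1,3-dioxolan-4-yl)methyl group, with 1 hydrogen-bond donor and a five-membered ring. No measurement shown here gives a reason for this result.

The compounds shown leave open whether a carboxylic acid or a piperidin-1-yl group on this same nitrogen would also fall within the scatter of compound 2. They also leave open what a longer chain between this nitrogen and the oxane ring would do.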